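A few compounds are considered here, and "the series" means these few. Any claim that something is new, unique, unknown or untested is made for them only; others in the source may bear on it.

Among the compounds with values here, in a functional assay on WI-38 VA13 cells (Homo sapiens) for cytotoxicity (on this read-out higher numbers stand for an effect only at larger amounts of compound and lower numbers for an effect already at smaller amounts), compound 2 `COCc1ccccc1C(=O)c1oc2cc(-c3ccccc3)cc(O)c2c1C` gives 0.1 ug/mL, the only number among the values shown. Compound 1 `Cc1c(C(=O)c2ccc(Oc3ccccc3)cc2)oc2cc(-c3ccccc3)cc(O)c12` gives > 4 ug/mL, a limit of the assay rather than a number. Compound 1 therefore stands at the limit of > 4 ug/mL in this assay, at which 1 of the 2 values shown sits. Compound 3 `CCc1ccc(C(=O)c2oc3cc(-c4ccccc4)cc(O)c3c2C)cc1` has not been measured. It differs from compound 2 by 4-ethylphenyl in place of 2-(methoxymethyl)phenyl on a carbonyl carbon. Within the data shown here, no step between two measured compounds is available, so the expectation rests on the change itself: a moderate move toward higher concentrations, beyond the usual scatter, is expected a 10-fold higher number from compound 2 to compound 3 (1.00 log units; beyond the scatter). Compound 3 is accordingly estimated at 1 ug/mL, between 0.2 ug/mL and 4 ug/mL.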

Compound 3, half-maximal effective concentration: > 4 ug/mL
Compound 3: only a limit was reported; the forecaster's own chance of this, stated with the estimate: 30%; middle value at least 4.0-fold (0.60 log units) from the limit.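

On a carbonyl carbon, 4-ethylphenyl in place of 2-(methoxymethyl)phenyl gives an at least 40-fold higher number from compound 2 to compound 3 (1.60 log units; beyond the scatter) in this assay, so this one change on the shared core is enough to separate the two compounds widely. The value of compound 3 is a limit and not a number: the limit of > 4 ug/mL in this assay, at which 2 of the 3 values shown sit. The step from compound 1 to compound 3 cannot be read.

The compounds shown leave open whether an aminomethyl group or a carboxylic acid in place of methoxymethyl would keep the low number of compound 2. Whether the oxygen of methoxymethyl or the place of the substituent on the phenyl ring accounts for the step also stays open.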